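A few compounds are considered here, and "the series" means these few. Any claim that something is new, unique, unknown or untested is made for them only; others in the source may bear on it.

Compound 3 `CCc1ccc(-c2cn3ccnc3c(-c3ccc4ncn(Cc5ccccc5)c4c3)n2)cc1` gives 54.2% in a functional assay on MOLT-4 cells (Homo sapiens) for inhibition, read by sulforhodamine B assay, with a stated time of 48 h, tested at 10 uM (on this read-out higher numbers stand for more inhibition at the one concentration tested (going by the name of the read-out) and lower numbers for less inhibition), and stands highest of the three numbers in hand: compound 2 `c1cn2cc(-c3ccsc3)nc(-c3ccc4ncn(C5CCCCC5)c4c3)c2n1` gives 30% and compound 1 `Fc1ccc(-c2cn3ccnc3c(-c3ccc4ncn(C5CCCCC5)c4c3)n2)cc1` gives 25.2%, both lying beyond the scatter below it. Compound 4 `O=Cc1ccc(-c2cn3ccnc3c(-c3ccc4ncn(Cc5ccccc5)c4c3)n2)cc1` differs from compound 3 in one place: formyl in place of ethyl on an aromatic carbon. For the measured compounds named here, the only measured step, a number 4.8 percentage points higher from compound 1 to compound 2 (within the scatter), swaps one whole aryl group for another and stays within the scatter; it offers no guide for replacing ethyl by formyl on a six-membered aromatic ring of carbon only. Going by the values given here, with no direct precedent, the step is expected to be small, most likely a modest decrease or none beyond the scatter, a number 9.2 percentage points lower from compound 3 to compound 4 (within the scatter). Compound 4 is estimated at 45%, within 25% to 65%.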

Compound 4, a percentage reported as inhibition, at one concentration (the size of the read-out at that concentration, not a potency): 58.7%
Compound 4: the middle estimate sits 13.7 percentage points below what was measured; the range from low to high includes it.
By their numbers in this assay, from the lowest: compounds 1 and 2 (each within the scatter of the next); then compounds 3 and 4 (each within the scatter of the next).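

At this position, para to a large group, going from 4-ethylphenyl to 4-formylphenyl gives a number 4.5 percentage points higher from compound 3 to compound 4 (within the scatter) in this assay. Formyl brings a hydrogen-bond acceptor and a double bond outside aromatic rings, neither of which ethyl has, yet this swap of two-heavy-atom groups does not separate the two compounds on this read-out. No measurement at hand offers an explanation for this result. Going by these compounds, whether a carboxylic acid, an amine or a longer alkyl chain at this position would also leave the number within the scatter remains open.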